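Bromo-methoxyphenyl chalcones and a cyclised analogue in MCF7 cells

The source may hold more compounds than are shown below. What is called first, only, known or untested is meant among the compounds shown, and "the series" means these compounds.

Compound 1 `COc1cc(Br)cc(/C=C/C(=O)c2ccccc2)c1O` is the open chalcone; in a functional assay on MCF7 cells (Homo sapiens) for antiproliferative activity, read by sulforhodamine B assay, with a stated time of 72 h, tested at 10 uM (a lower number here means a stronger effect, a higher number a weaker effect of the compound at the concentration tested), compound 1 gives 67%. Compound 2 `COc1cc(Br)cc(/C=C/C(=O)c2ccc(Cl)cc2)c1O` carries the change (chloro in place of hydrogen on an aromatic carbon), and in this assay compound 2 gives 53.3%. The step of a number 13.7 percentage points lower from compound 1 to compound 2 (beyond the scatter) follows. Compound 3 `COc1cc(Br)cc2c1OC(N)=C(C#N)C2CC(=O)c1ccccc1` has a different core, with the fused ring bearing the amino and nitrile groups; the difference between the two cores is not broken down here. In this assay compound 3 gives 99.1%, the highest of the three numbers, with compound 1 nearest and compound 2 furthest.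

Compound 4 `COc1cc(Br)cc2c1OC(N)=C(C#N)C2CC(=O)c1ccc(Cl)cc1` is not yet measured. It differs from compound 3 by chloro in place of hydrogen on an aromatic carbon, the same change as from compound 1 to compound 2, at the same place. For compound 4 the expected step is a number 8.1 percentage points lower from compound 3 to compound 4 (within the scatter), smaller than a number 13.7 percentage points lower from compound 1 to compound 2 (beyond the scatter) because compound 3 gives 99.1% and has little room left to move in that direction. In this assay compound 4 is estimated at 91%, between 76% and 103%.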

Compound 4, a percentage reported as activity, at one concentration (the size of the read-out at that concentration, not a potency): 49.6%
Compound 4: middle estimate off by 41.4 percentage points, on the high side; the whole stated range lies above it.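

Replacing phenyl by 4-chlorophenyl lowers the number on both cores, and in this assay the core of compound 3 shows a number 49.5 percentage points lower from compound 3 to compound 4 (beyond the scatter). The direction carries over between the two cores, but the size of the step does not: the same change on two cores in this assay, a number 13.7 percentage points lower (beyond the scatter) from compound 1 to compound 2 and a number 49.5 percentage points lower (beyond the scatter) from compound 3 to compound 4, 35.8 percentage points apart, beyond the scatter of two such steps. This rests on a single pair per core at one concentration, so it gives no potency, no cause for the gap, and no basis for predicting the size of the step on any further core.

From the compounds shown here alone, only hydrogen and chloro appear at this place on the phenyl ring, so it remains open whether fluoro, a carboxylic acid or a dimethylamino group there would also show a step that depends on the core. Also open, going by these compounds, is whether the gap between the two steps would persist if the nitrile on the fused ring gave way to an amide, or the amino group to a methylamino group.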